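The source may hold more compounds than are shown below. What is called first, only, known or untested is meant among the compounds shown, and "the series" means these compounds.

Measured in a functional assay on EBC-1 cells (Homo sapiens) for antiproliferative activity, with a stated time of 72 h; on this read-out higher numbers stand for weaker inhibition and lower numbers for stronger inhibition:
- compound 1 `N#Cc1ccc(-c2cc(F)c3ncc(Cc4ccc5ncccc5c4)n3c2)cc1F`: 145 nM
- compound 2 `O=C(NCCCN1CCCC1)c1ccc(-c2cc(F)c3ncc(Cc4ccc5ncccc5c4)n3c2)cc1F`: 161 nM
- compound 3 `O=C(NCC1CCCCN1)c1ccc(-c2cc(F)c3ncc(Cc4ccc5ncccc5c4)n3c2)cc1F`: 277 nM

Compound 3 gives 277 nM and lies within the scatter of both other compounds. Compound 4 `O=C(NC1CCCNC1)c1ccc(-c2cc(F)c3ncc(Cc4ccc5ncccc5c4)n3c2)cc1F` has not yet been measured. It carries piperidin-3-yl in place of (piperidin-2-yl)methyl on an amide-type nitrogen, a difference that reads (piperidin-3-yl in place of (piperidin-2-yl)methyl on an amide-type nitrogen). The closest measured change is the exchange of side chain in compound 3, a 1.7-fold higher number from compound 2 to compound 3 (0.24 log units; within the scatter). Replacing the cyano group with an amide side chain gave a 1.1-fold higher number from compound 1 to compound 2 (0.05 log units; within the scatter) and a 1.9-fold higher number from compound 1 to compound 3 (0.28 log units; within the scatter). Among the compounds with values here, none of these changes left the scatter, but the evidence rests on only three compounds, and none of them carries piperidin-3-yl. In this assay the expected outcome for this change is a 1.4-fold lower number from compound 3 to compound 4 (0.14 log units; within the scatter), which means no expected step beyond the scatter. For compound 4 the estimated value is 200 nM, with an expected range from 90 nM to 450 nM.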

Compound 4, half-maximal inhibitory concentration: 138 nM
The estimate for compound 4 lay 1.4-fold (0.16 log units) above the measured number; low and high end bracket the measured number.
By their numbers in this assay, from the lowest: compounds 4, 1, 2 and 3 (each within the scatter of the next).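

In this assay, the exchange of (piperidin-2-yl)methyl for piperidin-3-yl on the amide-type nitrogen gives a 2.0-fold lower number from compound 3 to compound 4 (0.30 log units; within the scatter) and so stays within the scatter with the ring now set directly on that nitrogen. Compared with the other two compounds, the result is a 1.2-fold lower number from compound 2 to compound 4 (0.07 log units; within the scatter) and a 1.1-fold lower number from compound 1 to compound 4 (0.02 log units; within the scatter) and shows that a third amide side chain at this place, of yet another shape, also leaves the read-out within the scatter of the nitrile. Nothing measured here explains these steps.

As far as these compounds go, it remains open whether piperidin-4-yl or cyclohexyl, which has carbon in place of the ring nitrogen, on the same amide-type nitrogen would stay within the scatter of compound 4. From the compounds shown here alone, it is also open whether any group at this place can produce a step beyond the scatter.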